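The compounds below may be only part of what the source reports. "The series", "measured", "known", "first", "only" and "open" are said of these compounds alone.

Measured so far:
compound 1 `Nc1ccccc1NC(=O)c1ccc(CSC(=S)N2CCN(Cc3ccccn3)CC2)cc1`: 23.4%
compound 2 `Nc1ccccc1NC(=O)c1ccc(CSC(=S)N2CCN(c3cccnc3)CC2)cc1`: 27.6%

In a functional assay on MGC-803 cells (Homo sapiens) for antiproliferative activity, read by CCK-8 assay, with a stated time of 72 h, tested at 2 uM (on this read-out higher numbers stand for a stronger effect at the one concentration tested and lower numbers for a weaker effect), compound 2 gives 27.6% and stands at the top of the two numbers measured. Within the data shown here, the only step known is a number 4.2 percentage points higher from compound 1 to compound 2 (within the scatter), which exchanges one group for another on the same ring nitrogen and stays within the scatter.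

Compound 3 `Nc1ccccc1NC(=O)c1ccc(CSC(=S)N2CCN(c3ccc(F)cc3)CC2)cc1` is not yet measured. It differs from compound 2 by 4-fluorophenyl in place of pyridin-3-yl on an amine nitrogen in a ring.

Among the measured compounds shown here, the one measured step bears on this change only in that it alters the group on the same amine nitrogen in a ring; no step involves the entering group, so nothing tells how it behaves. For the measured compounds named here, with the single known step within the scatter, the expectation for this assay is no step beyond the scatter, in either direction, and the estimated step is a number 1.6 percentage points lower from compound 2 to compound 3 (within the scatter). Compound 3 is therefore expected to give about 26%, within a range of 10% to 42%.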

Compound 3, a percentage reported as inhibition, at one concentration (the size of the read-out at that concentration, not a potency): 18.8%
Compound 3: middle estimate off by 7.2 percentage points, on the high side; measured number inside the range.
By their numbers in this assay, from the lowest: compounds 3, 1 and 2 (each within the scatter of the next).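

In this assay, 4-fluorophenyl on the amine nitrogen in a ring gives a number 8.8 percentage points lower from compound 2 to compound 3 (within the scatter), and the same group set against (pyridin-2-yl)methyl gives a number 4.6 percentage points lower from compound 1 to compound 3 (within the scatter). A ring of carbon only, with no hydrogen-bond acceptor counted for the group, can therefore stand on this nitrogen without a step beyond the scatter from either pyridine-bearing compound, so the hetero atom of the pyridine ring is not shown to matter here. Nothing available explains these numbers.

On these data alone, all three groups carry a six-membered aromatic ring, so it remains open whether a simple alkyl chain or a phenyl ring bearing a carboxylic acid would move the number beyond the scatter. Also open, as far as these compounds go, is whether any change on this nitrogen can separate compounds at the single concentration tested.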